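Hydroxy to methoxy from compound 2 to compound 4

The compounds below may be only part of what the source reports. "The series", "measured", "known", "first", "only" and "open" are said of these compounds alone.

- compound 1 `CC(=O)Nc1ccc2oc(-c3ccccc3F)c(O)c(=O)c2c1`: 47000 nM
- compound 2 `CC(=O)Nc1ccc2oc(-c3ccc(F)cc3)c(O)c(=O)c2c1`: 26000 nM
- compound 3 `Nc1ccc2oc(-c3ccc(F)cc3)c(O)c(=O)c2c1`: 4000 nM

All three values come from an ADME assay on THP-1 cells (Homo sapiens) for cytotoxicity, read by flow cytometry and propidium iodide staining, with a stated time of 72 h; a lower number here means a stronger inhibitor, a higher number a weaker inhibitor. Compound 2, at 26000 nM, has one near neighbour and one far neighbour on this scale: a 1.8-fold lower number from compound 1 to compound 2 (0.26 log units; within the scatter), and a 6.5-fold lower number from compound 2 to compound 3 (0.81 log units; beyond the scatter).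

Compound 4 `COc1c(-c2ccc(F)cc2)oc2ccc(NC(C)=O)cc2c1=O` is still unmeasured. It carries methyl in place of hydrogen on an oxygen on an aromatic ring, that is, methyl in place of hydrogen on an oxygen on an aromatic ring, or hydroxy to methoxy. Among the measured compounds shown here, no measured step touches this oxygen, so the data give no direct guide to the change. The two steps available show only what a single change has done elsewhere in the series. One stayed within the scatter, while a 6.5-fold lower number from compound 2 to compound 3 (0.81 log units; beyond the scatter) went beyond it, so a wide range is kept. No step beyond the scatter is expected in this assay. The expected size is a 1.3-fold higher number from compound 2 to compound 4 (0.13 log units; within the scatter). For compound 4 the estimated value is 35000 nM, with an expected range of 12000 nM to 100000 nM.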

Compound 4, half-maximal inhibitory concentration: > 125000 nM
Compound 4: no number, only a limit (the forecaster's own chance of this, stated with the estimate: 25%); at least 3.5-fold (0.55 log units) between middle value and limit.
By their numbers in this assay, from the lowest: compound 3; then compounds 2 and 1 (each within the scatter of the next). At a limit, above all of these: compound 4.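

In this assay compound 4 gives > 125000 nM as a limit of the assay, not a number. Among the compounds shown here, this is the first reading at this oxygen, and methyl in place of hydrogen here gives a step beyond the scatter (an at least 4.8-fold higher number from compound 2 to compound 4 (0.68 log units; beyond the scatter)), so the position is sensitive to this change, and the number moves the opposite way to the step at the nitrogen (a 6.5-fold lower number from compound 2 to compound 3 (0.81 log units; beyond the scatter)). The true size of the step stays unknown, since the reading ends at a limit: the limit of > 125000 nM in this assay, at which 1 of the 4 values shown sits.

The compounds shown leave open whether the higher number follows from losing the hydroxy hydrogen or from the added methyl, which an ethyl ether or an amine at this position would help to separate. Also open, on these data alone, is whether methoxy has the same effect on the free amine of compound 3.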